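The compounds below may be only part of what the source reports. "The series", "measured", "known", "first", "only" and "open" are said of these compounds alone.

Measured so far in an assay with Cystic fibrosis transmembrane conductance regulator (Rattus norvegicus) as the target; on this read-out lower numbers stand for tighter binding and higher numbers for weaker binding:
compound 1 `OCc1cc(-c2ccccc2OCc2ccc(Br)cc2)no1` gives 147000 nM;
compound 2 `OCCc1cc(-c2ccccc2OCc2ccc(Br)cc2)no1` gives 23000 nM;
compound 3 `COc1cccc(COc2ccccc2-c2cc(CO)on2)c1` gives 72000 nM.

Compound 1 and compound 2 share one core and differ only by hydroxymethyl in place of hydroxy on a saturated chain carbon bound to an aromatic carbon; the step was a 6.4-fold lower number from compound 1 to compound 2 (0.81 log units; beyond the scatter). Compound 3 carries a different core; the difference between the two cores is not broken down here. Compound 4 `COc1cccc(COc2ccccc2-c2cc(CCO)on2)c1` is not yet measured in this assay and is related to compound 3 by hydroxymethyl in place of hydroxy on a saturated chain carbon bound to an aromatic carbon, the same change at the same place as that between compound 1 and compound 2. Among the measured compounds shown here, compound 4 is expected to show a 5.5-fold lower number from compound 3 to compound 4 (0.74 log units; beyond the scatter), a step sized with some caution because a 6.4-fold lower number from compound 1 to compound 2 (0.81 log units; beyond the scatter) is the only example of this change measured so far, and on a different core. Compound 4 is estimated at 13000 nM, with a range from 4500 nM to 40000 nM.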

Compound 4, dissociation constant: 177000 nM
The estimate for compound 4 lay 14-fold (1.13 log units) below the measured number; the whole stated range lies below it.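

In this assay, the change from hydroxymethyl to 2-hydroxyethyl gives a 2.5-fold higher number from compound 3 to compound 4 (0.39 log units; beyond the scatter). The change does not carry from one core to the other, and the direction of the step reverses: the same change on two cores in this assay, a 6.4-fold lower number (0.81 log units; beyond the scatter) from compound 1 to compound 2 and a 2.5-fold higher number (0.39 log units; beyond the scatter) from compound 3 to compound 4, 16-fold (1.20 log units) apart, beyond the scatter of two such steps

With 2-hydroxyethyl present on both, 3-methoxyphenyl in place of 4-bromophenyl gives a 7.7-fold higher number from compound 2 to compound 4 (0.89 log units; beyond the scatter), so among these four compounds the chain change cannot be sized without regard to the core. This rests on a single pair per core and does not show which part of the cores accounts for the reversal, or how the change would behave on a third core.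

Open, from the compounds shown here alone, is whether a longer chain such as 3-hydroxypropyl, or an amine or a carboxylic acid in place of the hydroxy, would follow the trend of either core.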